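This account rests on a few compounds, and the source may have more. Where it says the series, first, only, none or still open, it means among the compounds named here.

Among the measured compounds shown here, compound 2 `Cc1ccc(CNC(=O)c2cccc(C(C)Oc3ccnc(Nc4cnn(C)c4)c3)c2)cc1` stands at the lower of the two numbers so far: in a functional assay on HCC78 cells (Homo sapiens) for antiproliferative activity, read by MTT assay, with a stated time of 48 h (on this read-out higher numbers stand for weaker inhibition and lower numbers for stronger inhibition), compound 2 gives 8900 nM, while compound 1 `COc1cc(CNC(=O)c2cccc(C(C)Oc3ccnc(Nc4cnn(C)c4)c3)c2)cc(OC)c1OC` gives 73900 nM, a change recorded as an 8.3-fold lower number from compound 1 to compound 2 (0.92 log units; beyond the scatter). Compound 3 `Cc1ccc(CNC(=O)c2cccc(C(C)Oc3ccnc(Nc4nc5ccccc5[nH]4)c3)c2)cc1` differs from compound 2 in another place, namely (1H-benzimidazol-2-yl in place of 1-methyl-1H-pyrazol-4-yl on a nitrogen on an aromatic ring). For the measured compounds named here, no measured step bears on this position; the single step, from one end of the molecule, says nothing about the other. The expectation for compound 3 is therefore broad and centred close to compound 2, at 6000 nM with a range of 1200 nM to 30000 nM, an estimated step of a 1.5-fold lower number from compound 2 to compound 3 (0.17 log units; within the scatter).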

Compound 3, half-maximal inhibitory concentration: > 100000 nM
Compound 3: no number, only a limit; the forecaster's own chance of this, stated with the estimate: 5%; at least 16-fold (1.22 log units) between middle value and limit.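

At this position, on a nitrogen on an aromatic ring, the choice of group clearly matters in this assay: 1H-benzimidazol-2-yl in place of 1-methyl-1H-pyrazol-4-yl gives an at least 11-fold higher number from compound 2 to compound 3 (1.05 log units; beyond the scatter). The change adds a six-membered aromatic ring of carbon only and a hydrogen-bond donor, and the earlier step gave no view of this part of the molecule. Compound 3 has only a limit, not a number: the limit of > 100000 nM in this assay, at which 1 of the 3 values shown sits.

The two additions arrive together, so the compounds shown cannot separate their contributions. Going by these compounds, how a smaller group such as an imidazole ring or a simple amine would behave here remains open.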